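The source may report more compounds than this note shows. Statements on the series, on what has been measured and on what is new or still open speak of the compounds shown alone.

In a functional assay on HCT-116 cells (Homo sapiens) for antiproliferative activity, read by MTT assay, with a stated time of 72 h (on this read-out higher numbers stand for weaker inhibition and lower numbers for stronger inhibition), compound 1 (`COc1ccc(N2CCN(C(=S)SCc3ccc4nc(N)nc(N)c4c3)CC2)cc1`) gives 2270 nM and compound 2 (`Nc1nc(N)c2cc(CSC(=S)N3CCN(c4ccc(Cl)c(Cl)c4)CC3)ccc2n1`) gives 6680 nM on the same core. For compound 3 (`Nc1nc(N)c2cc(CSC(=S)N3CCN(c4ccccc4F)CC3)ccc2n1`) the entry in this assay reads "not determined" (no result reported) and so offers no starting number. Compound 4 (`Nc1nc(N)c2cc(CSC(=S)N3CCN(c4ccc(F)cc4F)CC3)ccc2n1`) differs from it by fluoro in place of hydrogen on an aromatic carbon, taking 2-fluorophenyl to 2,4-difluorophenyl. Within the data shown here, the only measured step on this phenyl group is modest, a 2.9-fold higher number from compound 1 to compound 2 (0.47 log units; beyond the scatter) and it swaps 4-methoxyphenyl for 3,4-dichlorophenyl, more than a single fluoro. A step no larger than that is expected here, in no favoured direction, so the estimate leans on the span of compound 1 and compound 2 alone. Compound 4 is expected near 4000 nM in this assay with an estimated range from 1500 nM to 10000 nM at the two ends.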

Compound 4, half-maximal inhibitory concentration: 5150 nM
Estimate against measurement, compound 4: 1.3-fold (0.11 log units) below; the range from low to high includes it.
By their numbers in this assay, from the lowest: compound 1; then compounds 4 and 2 (each within the scatter of the next).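

The step from compound 3 to compound 4 cannot be read: compound 3 has no result in this assay, so the added fluoro cannot be sized on its own. The 2,4-difluorophenyl group instead matches the 3,4-dichlorophenyl group, with a 1.3-fold lower number from compound 2 to compound 4 (0.11 log units; within the scatter), while against 4-methoxyphenyl it shows a 2.3-fold higher number from compound 1 to compound 4 (0.36 log units; beyond the scatter), so both phenyl groups bearing halogens stand apart from compound 1. No supporting evidence bears on this result. What the compounds shown leave open is whether an amine or a carboxylic acid on this phenyl group would shift the number.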